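Propylthio series: hydroxyphenyl ethylidene in place of pyridylmethylidene

The compounds below may be only part of what the source reports. "The series", "measured", "known", "first", "only" and "open" are said of these compounds alone.

Of the compounds shown here, three of a shared core have been measured in a functional assay on MCF7 cells (Homo sapiens) for antiproliferative activity, read by MTT assay, with a stated time of 72 h; a higher number here means a weaker inhibitor, a lower number a stronger inhibitor. Compound 1 `CCCSc1nc(N/N=C(\C)c2ccccc2O)c2nnn(Cc3ccc(Cl)cc3)c2n1` gives 42600 nM, compound 2 `CCCSc1nc(N/N=C/c2cccnc2)c2nnn(Cc3ccccc3)c2n1` gives 58700 nM, and compound 3 `C/C(=N\Nc1nc(SCc2ccccc2)nc2c1nnn2Cc1ccccc1)c1ccccc1O` gives 950 nM. Compound 2 has the highest number of the three; the gap to compound 1 is within the scatter, while compound 3 lies well below, beyond the scatter. For the measured compounds named here, no pair among the measured compounds differs in a single place, so no step between them is counted.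

The next compound, compound 4 `CCCSc1nc(N/N=C(\C)c2ccccc2O)c2nnn(Cc3ccccc3)c2n1`, has not been measured. It is obtained from compound 2 by the change (a group of 10 heavy atoms (8 carbon, 1 nitrogen, 1 oxygen; one six-membered aromatic ring of carbon only) in place of a group of 8 heavy atoms (6 carbon, 2 nitrogen; one six-membered aromatic ring with 1 hetero atom), on a nitrogen on an aromatic ring). Compound 1 and compound 3 both carry the entering group, and their values bracket a wide range. The outcome for compound 4 is therefore uncertain in size, but the expectation is a lower number than that of compound 2, with an estimated step from a 3.9-fold lower number from compound 2 to compound 4 (0.59 log units; beyond the scatter), beyond the scatter. The estimate for compound 4 in this assay is 15000 nM, with a range from 3000 nM to 50000 nM, the width reflecting that compound 1 and compound 3 give quite different numbers.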

Compound 4, half-maximal inhibitory concentration: 11000 nM
For compound 4 the middle estimate is 1.4-fold (0.13 log units) above the measured one; the measured number falls inside the stated range.
By their numbers in this assay, from the lowest: compound 3; then compound 4; then compounds 1 and 2 (each within the scatter of the next).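

In this assay, for the compounds shown here, the group of 10 heavy atoms with a carbon-only aromatic ring, in place of the group of 8 heavy atoms with one hetero atom in its ring, on a nitrogen on an aromatic ring, gives a 5.3-fold lower number from compound 2 to compound 4 (0.73 log units; beyond the scatter) and is the first reading of this change with the rest of the molecule held constant. Compound 4 also separates the two other differences: hydrogen in place of chloro on an aromatic carbon gives a 3.9-fold lower number from compound 1 to compound 4 (0.59 log units; beyond the scatter), a modest step, whereas ethyl in place of phenyl on a saturated chain carbon bound to a sulfur gives a 12-fold higher number from compound 3 to compound 4 (1.06 log units; beyond the scatter), a large one that shows the wide spread among the compounds carrying the entering group is not set by the chloro alone. No measurement at hand accounts for any of these steps.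

From the compounds shown here alone, each change rests on a single pair, so whether the step from compound 2 to compound 4 carries over to a compound with phenyl on the saturated chain carbon remains open. Also open, going by these compounds, are the effects of a methoxy group in place of the hydroxyl, of fluoro in place of chloro, and of a cyclohexyl group in place of the phenyl on that chain carbon.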